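Pyrazole substituent swap on the glucagon receptor series

The compounds below may be only part of what the source reports. "The series", "measured", "known", "first", "only" and "open" are said of these compounds alone.

Measured so far, in an assay on cells for displacement of a labelled ligand from Glucagon receptor (Homo sapiens), in the presence of a further agent that is not named here; on this read-out lower numbers stand for stronger inhibition and higher numbers for weaker inhibition:
- compound 1, `CCCC(Oc1ccc(-n2cc3ccccc3n2)cc1)c1ccc(C(=O)NCCC(=O)O)cc1`, gives 290 nM
- compound 2, `CCCC(Oc1ccc(-n2cc(C#N)cn2)cc1)c1ccc(C(=O)NCCC(=O)O)cc1`, gives 4100 nM

Among the measured compounds shown here, compound 2 stands at the highest of the two numbers in this assay ; its only neighbour is compound 1, and the step of a 14-fold higher number from compound 1 to compound 2 (1.15 log units; beyond the scatter) separates them, with the change 4-cyano-1H-pyrazol-1-yl in place of 2H-indazol-2-yl on an aromatic carbon.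

Compound 3, `CCCC(Oc1ccc(-n2cc(F)cn2)cc1)c1ccc(C(=O)NCCC(=O)O)cc1`, is not yet measured. It differs from compound 2 by fluoro in place of cyano on an aromatic carbon, a fluoro in place of cyano on an aromatic carbon of the five-membered aromatic ring with 2 nitrogen.

For the measured compounds named here, only one step is known, and it exchanges the whole ring rather than this single group, so it does not speak directly to the cyano-to-fluoro exchange. Going by the values given here, no measured step therefore bears on this change, and the expectation is for no step beyond the scatter : compound 3 is expected at 3500 nM, within 1200 nM to 10000 nM, which means an estimated step of a 1.2-fold lower number from compound 2 to compound 3 (0.07 log units; within the scatter).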

Compound 3, inhibition constant: 1700 nM
Beside the measured number, compound 3's estimate is 2.1-fold (0.31 log units) above it; the measured number falls inside the stated range.
By their numbers in this assay, from the lowest: compound 1; then compound 3; then compound 2.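

Working notes: in this assay, a single-group exchange at this place on the five-membered aromatic ring with 2 nitrogen can now be read directly. With fluoro in place of cyano, the number moves a 2.4-fold lower number from compound 2 to compound 3 (0.38 log units; beyond the scatter), a modest step beyond the scatter, so the read-out responds to the group held here even with the ring itself unchanged. The 4-fluoro-1H-pyrazol-1-yl group still falls short of 2H-indazol-2-yl, with a 5.9-fold higher number from compound 1 to compound 3 (0.77 log units; beyond the scatter), so this exchange closes only part of the gap, and nothing on hand accounts for either step.

Open, as far as these compounds go, is where a chloro or methyl group at this place would fall relative to fluoro and cyano. Also open, from the compounds shown here alone, is how the ring without any group at this place would compare.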